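Notes on the step from compound 2 to compound 3

The compounds below may be only part of what the source reports. "The series", "measured", "known", "first", "only" and "open" are said of these compounds alone.

For the measured compounds named here, compound 2 `CC[C@H](C)[C@H](N)CN(C(=O)[C@@H]1C[C@H]1c1ccccc1)c1ccc(-c2ccc(C(=O)N(C)C)cc2)cc1` gives 980 nM in a functional assay for agonist activity at G protein-coupled receptor 88 (Homo sapiens), read by HTRF and cAMP accumulation (on this read-out higher numbers stand for an effect only at larger amounts of compound and lower numbers for an effect already at smaller amounts), the highest of the two numbers measured so far. Going by the values given here, its nearest neighbour, compound 1 `CC[C@H](C)[C@H](N)CN(C(=O)[C@@H]1C[C@H]1c1ccccc1)c1ccc(-c2ccc(COC(C)(C)C)cc2)cc1`, gives 280 nM in this assay, and the only measured step, a 3.5-fold higher number from compound 1 to compound 2 (0.54 log units; beyond the scatter), arose from dimethylcarbamoyl in place of (tert-butoxy)methyl on an aromatic carbon.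

Compound 3 `CC[C@H](C)[C@H](N)CN(C(=O)[C@@H]1C[C@H]1c1ccccc1)c1ccc(-c2ccc(NS(C)(=O)=O)cc2)cc1` is not yet measured. Among the compounds with values here, it differs from compound 2 by methanesulfonamido in place of dimethylcarbamoyl on an aromatic carbon; the change sits at the same position as the one already measured, but no step with methanesulfonamido is known, so that step gives only a rough scale, not a direction. Compound 3 is therefore expected to sit close to compound 2, with the estimated step of a 1.0-fold higher number from compound 2 to compound 3 (0.01 log units; within the scatter) unlikely to exceed the scatter by much. The estimate for compound 3 in this assay is 1000 nM, within 300 nM to 3500 nM.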

Compound 3, half-maximal effective concentration: 1200 nM
For compound 3 the middle estimate is 1.2-fold (0.08 log units) below the measured one; the measured number falls inside the stated range.
By their numbers in this assay, from the lowest: compound 1; then compounds 2 and 3 (each within the scatter of the next).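

In this assay, at this place para to a large group, methanesulfonamido and dimethylcarbamoyl are not told apart: the exchange gives a 1.2-fold higher number from compound 2 to compound 3 (0.09 log units; within the scatter), even though the entering group carries a hydrogen-bond donor and the leaving group none. Replacing (tert-butoxy)methyl with methanesulfonamido gives a 4.3-fold higher number from compound 1 to compound 3 (0.63 log units; beyond the scatter), so with a 3.5-fold higher number from compound 1 to compound 2 (0.54 log units; beyond the scatter) now beside it, compound 1 holds the lowest number of the three, with both steps from it beyond the scatter. Nothing available explains either the match between compound 2 and compound 3 or the gap to compound 1.

Still open, from the compounds shown here alone, is whether the lower number of compound 1 depends on the ether oxygen, the tert-butyl group or both. A plain alkyl chain, a primary amine or a carboxylic acid at this place would test how far the pattern extends.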